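Swapping a Hydroxy for a Chloro on an Inactive Sulfonamide

A few compounds are considered here, and "the series" means these few. Any claim that something is new, unique, unknown or untested is made for them only; others in the source may bear on it.

Compound 1 `O=S(=O)(Nc1ccc2oc(-c3ccccc3)nc2c1)c1ccccc1O` is a sulfonamide carrying a 2-hydroxyphenyl group. In an assay on isolated protein for inhibition of malate dehydrogenase, mitochondrial (Sus scrofa), with stated times of 45 min and 30 min (on this read-out lower numbers stand for stronger inhibition and higher numbers for weaker inhibition), compound 1 gives only > 63000 nM, which is a limit of the assay and not a measured number. Compound 2 `Cc1cccc(S(=O)(=O)Nc2ccc(-c3nc4ccccc4o3)cc2)c1` shares the sulfonamide link but places the groups differently. In this assay compound 2 also gives > 63000 nM, again a limit. Both values therefore sit at the limit of > 63000 nM in this assay, at which 2 of the 2 values shown sit, so neither compound shows measurable inhibition here, and compound 1 cannot be ranked against compound 2.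

Compound 3 `O=S(=O)(Nc1ccc2oc(-c3ccccc3)nc2c1)c1ccccc1Cl` has not yet been measured. It differs from compound 1 in one place: chloro in place of hydroxy on an aromatic carbon. Going by the values given here, no measured pair shows the effect of this change, so there is nothing to point to for its size or direction. Compound 3 is expected to remain without measurable inhibition, with an estimated step that the limit leaves unreadable from compound 1 to compound 3. Compound 3 is estimated at 80000 nM, within 20000 nM to 300000 nM, most likely reported as a limit.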

Compound 3, half-maximal inhibitory concentration: > 63000 nM
Compound 3 ended at the assay's limit (the forecaster's own chance of this, stated with the estimate: 85%); the middle value is on the limit's open side.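

Compound 1 and compound 3 both give only a limit, not a measured number, so swapping hydroxy for chloro yields no readable step: the limit of > 63000 nM in this assay, at which 3 of the 3 values shown sit.

The compounds shown leave open whether any change to this shared structure would give measurable inhibition.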